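A few compounds are considered here, and "the series" means these few. Any claim that something is new, unique, unknown or untested is made for them only; others in the source may bear on it.

Measured so far in a physicochemical assay for solubility, using the shake flask method, in simulated intestinal fluid, measured as kinetic solubility, with a stated time of 2 h, at 25 degrees C, at pH 6.5; a higher number here means a more soluble compound, a lower number a less soluble compound:
compound 1 `Cc1noc(-c2nc(C)c3c(c2N)C(=O)N(Cc2ccc(-n4cccn4)cc2)C3=O)n1` gives < 5000 nM, which is a limit of the assay and not a number.
compound 2 `Cc1noc(-c2nc(C)c3c(c2N)C(=O)N(Cc2cccc(C(F)(F)F)c2)C3=O)n1` gives < 5000 nM, again a limit of the assay rather than a number.

Compound 2 therefore stands at the edge of what this assay can report: only a limit is known for it, and the same holds for compound 1, so that both of the values shown sit together at the limit of < 5000 nM in this assay, at which 2 of the 2 values shown sit. Going by the values given here, no step between measured compounds can be drawn from this pair, since neither value is a number.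

Compound 3 `Cc1noc(-c2nc(C)c3c(c2N)C(=O)N(Cc2ccc(C(N)=O)cc2)C3=O)n1` has not yet been measured in this assay. It differs from compound 2 in one place: 4-carbamoylphenyl in place of 3-(trifluoromethyl)phenyl on a saturated chain carbon bound to an amide-type nitrogen in a ring. Among the compounds with values here, with no measured step to lean on, the account can only offer an expectation. The step from compound 2 to compound 3 is expected to run upward, beyond the usual scatter, as an at least 3.0-fold higher number from compound 2 to compound 3 (0.47 log units; beyond the scatter). Compound 3 is accordingly estimated at 15000 nM, with a range from 3000 nM to 60000 nM.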

Compound 3, solubility: < 5000 nM
Compound 3 gave a limit, no number; the forecaster's own chance of this, stated with the estimate: 30%; middle value at least 3.0-fold (0.47 log units) away from the limit.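

Compound 3 also gives only a limit and not a number in this assay, so no step from compound 1 or compound 2 to compound 3 can be read: the limit of < 5000 nM in this assay, at which 3 of the 3 values shown sit.

The compounds shown leave open whether compound 1, compound 2 and compound 3 differ from one another in solubility at all.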